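From 4-fluorophenyl to 2-chlorophenyl on the shared core

This account rests on a few compounds, and the source may have more. Where it says the series, first, only, none or still open, it means among the compounds named here.

In a functional assay on HL-60 cells (Homo sapiens) for antiproliferative activity, with a stated time of 72 h (a higher number here means a weaker inhibitor, a lower number a stronger inhibitor), compound 2 (`Nc1ncnn2c([C@@H]3O[C@H](CO)[C@@H](O)[C@H]3O)cc(-c3ccc(F)cc3)c12`) gives the highest of the three numbers at 68300 nM, ahead of compound 3 (`Nc1ncnn2c([C@@H]3O[C@H](CO)[C@@H](O)[C@H]3O)cc(/C=C/c3ccccc3)c12`) at 2000 nM and compound 1 (`CCCC#Cc1cc([C@@H]2O[C@H](CO)[C@@H](O)[C@H]2O)n2ncnc(N)c12`) at 200 nM. Replacing the pent-1-yn-1-yl group with 4-fluorophenyl costs much, with a 340-fold higher number from compound 1 to compound 2 (2.53 log units; beyond the scatter). Replacing it with 2-phenylethenyl costs less, with a 10-fold higher number from compound 1 to compound 3 (1.00 log units; beyond the scatter), and the gap between those two groups appears as a 34-fold lower number from compound 2 to compound 3 (1.53 log units; beyond the scatter). The change to compound 4 (`Nc1ncnn2c([C@@H]3O[C@H](CO)[C@@H](O)[C@H]3O)cc(-c3ccccc3Cl)c12`) is 2-chlorophenyl in place of 4-fluorophenyl on an aromatic carbon. All three measured steps exchange different kinds of group, and none of them moves or changes a halogen on a phenyl ring, so they offer only indirect guidance. Both compounds carry a halogenated phenyl ring at this carbon, so a small step in this assay is expected, probably within the scatter. The expected step is a 1.7-fold lower number from compound 2 to compound 4 (0.23 log units; within the scatter). For compound 4 the estimated value is 40000 nM, with an expected range from 9000 nM to 100000 nM.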

Compound 4, half-maximal inhibitory concentration: > 100000 nM
Compound 4: no number, only a limit; the forecaster's own chance of this, stated with the estimate: 20%; middle value at least 2.5-fold (0.39 log units) from the limit.
By their numbers in this assay, from the lowest: compound 1; then compound 3; then compound 2. At a limit, above all of these: compound 4.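

In this assay compound 4 gives only a limit, not a number: the limit of > 100000 nM in this assay, at which 1 of the 4 values shown sits. Going by these compounds, the exchange of one halogenated phenyl group for the other can be read only as a floor, an at least 1.4-fold higher number from compound 2 to compound 4 (0.16 log units; that floor lies within the scatter), so its true size stays unknown and it cannot be said to exceed the scatter. The wider comparisons are clearer, with an at least 50-fold higher number from compound 3 to compound 4 (1.69 log units; beyond the scatter) and an at least 500-fold higher number from compound 1 to compound 4 (2.69 log units; beyond the scatter), so this carbon now has two directly attached halogenated phenyl groups that both lie far on the weak side of the pent-1-yn-1-yl group of compound 1.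

The compounds shown leave open whether an unsubstituted phenyl group would behave like these two halogenated ones. They also leave open how a shorter alkyne such as ethynyl, or an alkyne chain ending in a hydroxyl group, would compare with pent-1-yn-1-yl.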